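The source may report more compounds than this note shows. Statements on the series, on what has been measured and on what is new or still open speak of the compounds shown alone.

Measured compounds:
compound 1, `O=C(c1ccc(NCc2cncn2Cc2ccc(-c3ccccc3)cc2)cc1-c1ccccc1)N1CCCCC1` — in a toxicity assay on NIH3T3 cells (Mus musculus) for cytotoxicity, read by resazurin assay (a higher number here means that more compound is needed for the effect, a lower number that less compound is needed), compound 1 gives > 1000 nM
compound 2, `COC(=O)c1ccc(NCc2cncn2Cc2ccccc2Cl)cc1-c1ccccc1` — in this assay compound 2 gives 10000 nM

The reading for compound 1 is a limit of the assay, not a number: the limit of > 1000 nM in this assay, at which 1 of the 2 values shown sits. Compound 1 therefore stands only at the cautious end of what this assay can report, and its true position beyond that point is open. Compound 2 reads as a plain number. Going by the values given here, no step between the two measured compounds is computed here, and the two values show only that both compounds sit in the weakly cytotoxic range of this assay.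

Compound 3, `CCCC(=O)c1ccc(NCc2cncn2Cc2ccc(-c3ccccc3)cc2)cc1-c1ccccc1`, is not yet measured. It differs from compound 1 in one place: propyl in place of piperidin-1-yl on a carbonyl carbon. Nothing measured in the series touches this position, so the direction of the step is not fixed by the data. The expectation is a step from compound 1 to compound 3 of no more than the scatter of this assay, a step that the limit leaves unreadable from compound 1 to compound 3, with a real chance that compound 3 again returns only a limit. On that basis compound 3 is estimated at 4000 nM, within a range of 1200 nM to 15000 nM.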

Compound 3, half-maximal effective concentration: > 10000 nM
Compound 3: a limit, no number (the forecaster's own chance of this, stated with the estimate: 45%); middle value at least 2.5-fold (0.39 log units) from the limit.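

In this assay compound 3 gives > 10000 nM, which is a limit of the assay. Going by these compounds alone, compound 1 gives > 1000 nM, also a limit, and no step between compound 1 and compound 3 can be read. Still open, going by these compounds, is where each compound truly lies past its limit, and whether propyl in place of piperidin-1-yl changes cytotoxicity at all.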